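The source may report more compounds than this note shows. Statements on the series, on what has been measured and on what is new or still open speak of the compounds shown alone.

In an assay on microsomes from brain for inhibition of Fatty-acid amide hydrolase 1 (Rattus norvegicus), read by fluorescence and HPLC, with a stated time of 60 min (on this read-out lower numbers stand for stronger inhibition and higher numbers for weaker inhibition), compound 2, `COC(=O)c1ccc(-c2nnn(CC(=O)C(C)Oc3ccc(Oc4ccc(F)cc4)cc3)n2)cc1`, gives 36 nM, the lowest of the two numbers at hand. Among the compounds with values here, the only other measured compound, compound 1, `CC(Oc1ccc(Oc2ccc(Cl)cc2)cc1)C(=O)Cn1nnc(-c2ccc(Cl)cc2)n1`, gives 76 nM in this assay, a higher number that lies beyond the scatter; since the two structures differ in more than one place, their values show only this gap and no single step.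

Compound 3, `COC(=O)c1ccc(-c2nnn(CC(=O)C(C)Oc3ccc(Oc4ccc(Cl)cc4)cc3)n2)cc1`, has not yet been measured in this assay. It differs from compound 2 by chloro in place of fluoro on an aromatic carbon, para to a large group. Within the data shown here, no measured pair shows this change by itself, so the data give no step for it. The expected step of a 1.2-fold lower number from compound 2 to compound 3 (0.08 log units; within the scatter) is therefore small and within the usual scatter, with no clear direction. The estimate for compound 3 in this assay is 30 nM, with a range from 12 nM to 80 nM.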

Compound 3, half-maximal inhibitory concentration in the Fatty-acid amide hydrolase 1 assay: 47 nM
Compound 3: middle estimate off by 1.6-fold (0.19 log units), on the low side; the range from low to high includes it.
By their numbers in the Fatty-acid amide hydrolase 1 assay, from the lowest: compounds 2, 3 and 1 (each within the scatter of the next, the first and the last beyond it).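

At this position, on an aromatic carbon para to a large group, the change from 4-fluorophenoxy to 4-chlorophenoxy can now be read by itself: in the Fatty-acid amide hydrolase 1 assay it gives a 1.3-fold higher number from compound 2 to compound 3 (0.12 log units; within the scatter), so this read-out does not separate the two halogens. Methoxycarbonyl in place of chloro on an aromatic carbon can also be read now, and in the Fatty-acid amide hydrolase 1 assay it too stays within the scatter, with a 1.6-fold lower number from compound 1 to compound 3 (0.21 log units; within the scatter). In a physicochemical assay for lipophilicity, read by HPLC, tested at 5 mM (a lower number here means a more polar compound, a higher number a more lipophilic compound), compound 2 gives 5.4 and compound 3 gives 6.1, so the halogen change does register, although inhibition does not separate the pair: the measured partition coefficient of compound 2, 5.4, and of compound 3, 6.1, a number 0.70 log units higher (beyond the scatter)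

The compounds shown leave open how an amine or a carboxylic acid would read at this position, since only two halogens have been compared there. On these data alone, whether the same halogen change would read alike on a different core also remains open.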